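Chain Lengthening on Two Related Antagonist Cores

A few compounds are considered here, and "the series" means these few. Any claim that something is new, unique, unknown or untested is made for them only; others in the source may bear on it.

Compound 1 `CCCCN(CCC)c1nc(C)nc2c(-c3ccc(OC)nc3C)c(C)nn12` gives 2.4 nM in an assay on cell membranes for displacement of a labelled ligand from corticotropin-releasing factor receptor 1 (Rattus norvegicus); a lower number here means a stronger inhibitor, a higher number a weaker inhibitor. Compound 2 `CCCCN(C)c1nc(C)nc2c(-c3ccc(OC)nc3C)c(C)nn12` gives 8.1 nM in this assay. Compound 3 `CCN(CC)c1nc(C)nc2c(-c3c(C)cc(N(C)C)nc3C)c(C)nn12` gives 58 nM in this assay.

Compound 1 and compound 2 share one core and differ only by ethyl in place of hydrogen on a saturated chain carbon bound to a nitrogen on an aromatic ring. That change produced a 3.4-fold lower number from compound 2 to compound 1 (0.53 log units; beyond the scatter). Compound 3 carries a different core; the difference between the two cores is not broken down here, and its value in this assay is the highest of the three, with compound 2 the nearest of the other two.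

Compound 4 `CCCCN(CC)c1nc(C)nc2c(-c3c(C)cc(N(C)C)nc3C)c(C)nn12` differs from compound 3 by ethyl in place of hydrogen on a saturated chain carbon, two bonds along the chain from a nitrogen on an aromatic ring. The group entering and the group leaving are the same as between compound 2 and compound 1, but the place is not identical: in the earlier pair the carbon is bound to a nitrogen on an aromatic ring, here it is two bonds along the chain from such a nitrogen. It is therefore the same kind of change, not the same change.

The estimate for compound 4 rests on compound 3 with 58 nM and on the earlier step of a 3.4-fold lower number from compound 2 to compound 1 (0.53 log units; beyond the scatter). A somewhat smaller gain is expected, namely a 2.4-fold lower number from compound 3 to compound 4 (0.38 log units; beyond the scatter). Compound 4 is thus estimated at 24 nM, with a likely range from 10 nM to 60 nM.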

Compound 4, half-maximal inhibitory concentration: 32.8 nM
Compound 4: middle estimate off by 1.4-fold (0.14 log units), on the low side; the measured number falls inside the stated range.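

On the second core, in this assay, ethyl in place of hydrogen gives a 1.8-fold lower number from compound 3 to compound 4 (0.25 log units; within the scatter), a step that on its own cannot be told apart from repeat measurement. Set beside the earlier pair, the two steps do not differ: the same change on two cores in this assay, a 3.4-fold lower number (0.53 log units; beyond the scatter) from compound 2 to compound 1 and a 1.8-fold lower number (0.25 log units; within the scatter) from compound 3 to compound 4, 1.9-fold (0.28 log units) apart, within the scatter of two such steps. For the compounds shown here, this agrees with the change carrying from one core to the other, but it does not show that the gain transfers unchanged: only two pairs are available, the place on the chain is not identical in them, and only the earlier step stands clear of the scatter.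

The compounds shown leave open whether a longer chain, such as pentyl, or a chain ending in an amine or a carboxylic acid would follow the same course on either core. Also open is how much of the gap between the two series belongs to the core itself, as each pair shown stays on a single core.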